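From a Nitrile Tail to a Benzyl Thiourea

The source may report more compounds than this note shows. Statements on the series, on what has been measured and on what is new or still open speak of the compounds shown alone.

The compounds measured so far:
compound 1, `CCN(C)C(=S)SC(=S)N(C)C`; in an ADME assay on HeLa cells (Homo sapiens) for cytotoxicity, read by MTT assay, with a stated time of 24 h (a higher number here means a weaker inhibitor, a lower number a stronger inhibitor), compound 1 gives 2070000 nM.
compound 2, `CN1CCN(C(=S)SC(=S)N(C)C)CC1`; in this assay compound 2 gives 1220000 nM.
compound 3, `CN(C)C(=S)SC(=S)N1CCN(C(=S)SCCCC#N)CC1`; in this assay compound 3 gives only a limit, > 5000000 nM.

Compound 3 therefore stands apart from the two compounds with numbers: it sits at the limit of > 5000000 nM in this assay, at which 1 of the 3 values shown sits, which is a limit of the assay and not a measured concentration. Compound 1 and compound 2 each give a number, so both are seen to act within the tested range, while compound 3 is not.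

Compound 4, `CN(C)C(=S)SC(=S)N1CCN(C(=S)NCc2ccccc2)CC1`, keeps the core of compound 3 and changes one end of it: benzylamino in place of (3-cyanopropyl)sulfanyl on a thiocarbonyl carbon. In words, benzylamino in place of (3-cyanopropyl)sulfanyl on a thiocarbonyl carbon.

Among the compounds with values here, no pair of compounds that differ in only one place has been measured, so there is no step to lean on. The expectation must start from a limit, and the expected step from compound 3 to compound 4 is an at least 1.6-fold lower number from compound 3 to compound 4 (0.22 log units; that floor lies within the scatter) in this assay, a modest move toward a stronger effect that may or may not clear the scatter. Compound 4 is thus estimated at 3000000 nM, with a likely range from 800000 nM to 10000000 nM.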

Compound 4, half-maximal inhibitory concentration: > 5000000 nM
Compound 4 was reported as a limit; the forecaster's own chance of this, stated with the estimate: 40%; middle value at least 1.6-fold (0.22 log units) from the limit.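

In this assay compound 4 gives > 5000000 nM, which is a limit of the assay and not a number. Compound 3 is also reported only as a limit, so no step between compound 3 and compound 4 can be read: the limit of > 5000000 nM in this assay, at which 2 of the 4 values shown sit.

The compounds shown leave open whether benzylamino in place of (3-cyanopropyl)sulfanyl on a thiocarbonyl carbon changes the effect at all.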